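Amide aryl variation on a shared core

The source may report more compounds than this note shows. Statements on the series, on what has been measured and on what is new or still open speak of the compounds shown alone.

Measured in a functional assay on HepG2 cells (Homo sapiens) for antiproliferative activity, read by CCK-8 assay, with a stated time of 72 h; a higher number here means a weaker inhibitor, a lower number a stronger inhibitor:
compound 1 `O=C(Nc1cccc(-c2oc3cc(-c4ccc(F)cc4)ccc3c(=O)c2O)c1)c1ccccc1F` gives 10100 nM
compound 2 `Cc1ccc(C(=O)Nc2cccc(-c3oc4cc(-c5ccc(F)cc5)ccc4c(=O)c3O)c2)cc1` gives 2320 nM
compound 3 `Cc1cc(C(=O)Nc2cccc(-c3oc4cc(-c5ccc(F)cc5)ccc4c(=O)c3O)c2)ccc1F` gives 9540 nM

Compound 3 stands second highest of the three numbers in this assay. Going by the values given here, its nearest neighbour is compound 1, a gap within the scatter a 1.1-fold lower number from compound 1 to compound 3 (0.02 log units; within the scatter); the only step beyond the scatter is a 4.1-fold higher number from compound 2 to compound 3 (0.61 log units; beyond the scatter).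

Compound 4 `CCCc1ccc(C(=O)Nc2cccc(-c3oc4cc(-c5ccc(F)cc5)ccc4c(=O)c3O)c2)cc1` is the next member. 4-propylphenyl in place of 4-fluoro-3-methylphenyl on a carbonyl carbon

Among the compounds with values here, two measured steps bear on this change. The move to 4-methylphenyl gave a 4.4-fold lower number from compound 1 to compound 2 (0.64 log units; beyond the scatter), and the move away from it gave a 4.1-fold higher number from compound 2 to compound 3 (0.61 log units; beyond the scatter). Compound 4 carries 4-propylphenyl, a longer chain in the same position as the methyl of compound 2, so the step in this assay is expected to run downward, toward the number of compound 2. A step of about a 3.2-fold lower number from compound 3 to compound 4 (0.50 log units; beyond the scatter) is expected. Compound 4 is estimated at 3000 nM, with a range from 1200 nM to 8000 nM.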

Compound 4, half-maximal inhibitory concentration: 51500 nM
For compound 4 the middle estimate is 17-fold (1.23 log units) below the measured one, outside the stated range (above it).
By their numbers in this assay, from the lowest: compound 2; then compounds 3 and 1 (each within the scatter of the next); then compound 4.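

Within this series, chain length at this position has a large effect in this assay: going from the methyl of 4-methylphenyl to the propyl of 4-propylphenyl gives a 22-fold higher number from compound 2 to compound 4 (1.35 log units; beyond the scatter). Going by these compounds alone, the earlier compounds showed 4-methylphenyl as the only group that stood apart, with a lower number, whereas 4-propylphenyl stands apart in the opposite direction, as a 5.4-fold higher number from compound 3 to compound 4 (0.73 log units; beyond the scatter) and a 5.1-fold higher number from compound 1 to compound 4 (0.71 log units; beyond the scatter) show. Compound 4 is therefore the weakest of the four, and a para-like alkyl trend cannot be assumed from compound 2 alone.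

No evidence at hand bears on the cause of this loss. The compounds shown leave open whether 4-ethylphenyl falls nearer compound 2 or compound 4, and whether a chain of the same length ending in an amine or a carboxylic acid would behave like the propyl group.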